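This account rests on a few compounds, and the source may have more. Where it says the series, first, only, none or still open, it means among the compounds named here.

The measured compounds:
Compound 1, `CC(C)(Oc1ccc(Cl)cc1)C(=O)NCCOC(=S)Nc1ccc([N+](=O)[O-])cc1Cl`, gives 0.0283 h in an ADME assay for pharmacokinetics, in phosphate buffer, tested at 60 uM; on this read-out higher numbers stand for a longer-lived compound and lower numbers for a shorter-lived compound.
Compound 2, `CC(C)(Oc1ccc(Cl)cc1)C(=O)Oc1ccc(-c2cc(=S)ss2)cc1`, gives 0.07 h in this assay.
Compound 3, `Cc1cnc(C(=O)Oc2ccc(C(N)=S)cc2)c[n+]1[O-]`, gives 0.065 h in this assay.

Compound 1 has the lowest of these three numbers in this assay; compound 3 and compound 2 both lie above it by more than the usual scatter, so compound 1 is the shortest-lived of the three. Compound 4, `CC(C)(Oc1ccc(Cl)cc1)C(=O)NCCOC(=S)Nc1ccc(F)cc1`, differs from compound 1 in one place: 4-fluorophenyl in place of 2-chloro-4-nitrophenyl on an amide-type nitrogen. Within the data shown here, no measured pair shows this change, so its effect cannot be read from the data. The shared core of compound 1 is kept, and the change is expected to bring only a small shift, a slight lengthening at most: a 1.8-fold higher number from compound 1 to compound 4 (0.25 log units; within the scatter). Compound 4 is therefore estimated at 0.05 h, with a range from 0.02 h to 0.15 h.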

Compound 4, half-life: 0.02 h
The estimate for compound 4 lay 2.5-fold (0.40 log units) above the measured number, within the range that was stated.
By their numbers in this assay, from the lowest: compounds 4 and 1 (each within the scatter of the next); then compounds 3 and 2 (each within the scatter of the next).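

Putting 4-fluorophenyl in place of 2-chloro-4-nitrophenyl on the amide-type nitrogen next to the thiocarbonyl carbon gives a small step in this assay (a 1.4-fold lower number from compound 1 to compound 4 (0.15 log units; within the scatter)). The nitro group and the chlorine can therefore both leave this aryl group without the half-life separating the two compounds. Nothing available explains this outcome. Still open, on these data alone, is whether a non-aromatic group on this nitrogen, such as cyclohexyl or methyl, would change the half-life. As far as these compounds go, the effect of a carbonyl in place of the thiocarbonyl also remains open.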